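Swapping a methoxyphenyl for a dihydroxyphenyl

The compounds below may be only part of what the source reports. "The series", "measured", "known", "first", "only" and "open" are said of these compounds alone.

Three measured compounds set the scene. Compound 1 `CCOC(=O)c1cnn(-c2nc(-c3ccc(OC)cc3)c(C#N)c(=O)n2C)c1N` gives 59 ug/mL in a functional assay, with a stated time of 20 min; a lower number here means a stronger inhibitor, a higher number a weaker inhibitor. Compound 2 `CN(C)c1ccc(-c2nc(NN)n(C)c(=O)c2C#N)cc1` gives 81 ug/mL in this assay, and compound 3 `Cn1c(NN)nc(-c2ccccc2Cl)c(C#N)c1=O` gives 58 ug/mL in this assay. Compound 1 stands second highest of these three numbers, but its gaps to compound 3 and to compound 2 both lie within the scatter, so the three cannot be told apart here. Compound 4 `CCOC(=O)c1cnn(-c2nc(-c3cccc(O)c3O)c(C#N)c(=O)n2C)c1N` is not yet measured; it carries 2,3-dihydroxyphenyl in place of 4-methoxyphenyl on an aromatic carbon. Among the compounds with values here, no measured pair shows a comparable change, so the data offer no step to lean on. The change is expected to move the number little, and a 1.2-fold lower number from compound 1 to compound 4 (0.07 log units; within the scatter) is estimated to stay within the scatter. Compound 4 is therefore expected to give 50 ug/mL in this assay, with a range from 20 ug/mL to 130 ug/mL.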

Compound 4, half-maximal inhibitory concentration: 41 ug/mL
For compound 4 the middle estimate is 1.2-fold (0.09 log units) above the measured one; measured number inside the range.
By their numbers in this assay, from the lowest: compounds 4, 3, 1 and 2 (each within the scatter of the next).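

Within the data shown here, this gives the first step at this position: in this assay, 2,3-dihydroxyphenyl in place of 4-methoxyphenyl gives a 1.4-fold lower number from compound 1 to compound 4 (0.16 log units; within the scatter). The entering group carries hydrogen-bond donors and the leaving group carries none, yet compound 4 cannot be told apart from compound 1 on this number. Nothing available explains this outcome. Going by these compounds, whether an amine or a carboxylic acid on this phenyl ring would move the number beyond the scatter stays open. So does what a single hydroxyl would do there.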